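A few compounds are considered here, and "the series" means these few. Any claim that something is new, unique, unknown or untested is made for them only; others in the source may bear on it.

Two compounds of this small set share one core. Compound 1 `O=C1N=C(O)S/C1=C\c1ccc(OCCC2CCCCC2)cc1Cl` carries a long saturated chain ending in a six-membered ring on the oxygen of its aromatic ring, and in an assay for inhibition of 15-hydroxyprostaglandin dehydrogenase [NAD(+)] (Homo sapiens), read by fluorescence and spectrophotometry (on this read-out lower numbers stand for stronger inhibition and higher numbers for weaker inhibition), compound 1 gives 13 nM. Compound 2 `Cc1ncsc1CCOc1ccc(/C=C2\SC(=O)NC2=O)cc1Cl` carries instead a 2-(4-methyl-1,3-thiazol-5-yl)ethyl group on that oxygen, and in this assay compound 2 gives 5170 nM. Compound 2 thus stands at the highest of the two numbers. The gap between compound 2 and compound 1 lies well beyond the usual scatter, and compound 2 is the weaker inhibitor of the pair.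

Compound 3 `O=C1NC(=O)/C(=C/c2ccc(OC(=O)c3cccs3)c(Cl)c2)S1` is not yet measured. It differs from compound 2 in one place: (thiophen-2-yl)carbonyl in place of 2-(4-methyl-1,3-thiazol-5-yl)ethyl on an oxygen on an aromatic ring. Among the measured compounds shown here, no measured pair shows this kind of exchange, so the expectation rests on the two values alone. A shorter aromatic group directly attached through a carbonyl is expected to move the number downward from compound 2, by a 5.2-fold lower number from compound 2 to compound 3 (0.71 log units; beyond the scatter), but with wide uncertainty. Compound 3 is therefore estimated at 1000 nM, within a range from 150 nM to 7000 nM.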

Compound 3, half-maximal inhibitory concentration: 264 nM
Beside the measured number, compound 3's estimate is 3.8-fold (0.58 log units) above it, and the stated range covers the measured number.
By their numbers in this assay, from the lowest: compound 1; then compound 3; then compound 2.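

In this assay, among the compounds shown here, this single exchange on an oxygen on an aromatic ring gives a 20-fold lower number from compound 2 to compound 3 (1.29 log units; beyond the scatter), a large step, and it is the first direct sign that the group at this position can change the reading while the rest of the molecule stays the same. The step comes between two groups that match in hydrogen-bond donors and acceptors and that each hold a five-membered aromatic ring, so those counts do not separate them, whereas the hetero atoms of the ring and the double bond outside aromatic rings do differ. No measurement at hand ties the step to any one of these differences.

The link and the ring change together here, so the compounds shown leave open which of the two goes with the lower number, and a 2-(thiophen-2-yl)ethyl group on the same oxygen would help to separate them. As far as these compounds go, it also remains open how a group without a five-membered aromatic ring, such as a benzoyl group or a plain butyl chain, would read at this position.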